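A few compounds are considered here, and "the series" means these few. Any claim that something is new, unique, unknown or untested is made for them only; others in the source may bear on it.

Three compounds built on one shared core were tested in an ADME assay on NCM460 cells (Homo sapiens) for cytotoxicity, read by MTT assay, with a stated time of 72 h; a lower number here means a stronger inhibitor, a higher number a weaker inhibitor. Compound 1 `COc1ccc(NC(=O)c2cccc(/C=C3\CC(=O)N(c4ccccc4)C3=O)c2)cc1` gives > 100000 nM, which is a limit of the assay rather than a number. Compound 2 `O=C(Nc1cccc(F)c1)c1cccc(/C=C2\CC(=O)N(c3ccccc3)C2=O)c1` gives > 100000 nM, again only a limit. Compound 3 `CCCCCN1C(=O)C/C(=C\c2cccc(C(=O)Nc3ccc(OC)cc3)c2)C1=O` gives > 100000 nM, also a limit.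

Compound 2 differs from compound 1 by 3-fluorophenyl in place of 4-methoxyphenyl on an amide-type nitrogen, and the step is a step that the two limits leave unreadable from compound 1 to compound 2. Compound 3 differs from compound 1 by pentyl in place of phenyl on an amide-type nitrogen in a ring, and that step is a step that the two limits leave unreadable from compound 1 to compound 3.

Compound 4 `CCCCCN1C(=O)C/C(=C\c2cccc(C(=O)Nc3cccc(F)c3)c2)C1=O` has not yet been measured. It differs from compound 3 by 3-fluorophenyl in place of 4-methoxyphenyl on an amide-type nitrogen. The surroundings of the changed group are the same word for word as in the change from compound 1 to compound 2, so the same change is made twice among these compounds, though the cores differ as described above.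

Because every measured value sits at the limit of > 100000 nM in this assay, at which 3 of the 3 values shown sit, the earlier step gives no readable size. The step from compound 3 to compound 4 is expected to be a number no higher from compound 3 to compound 4 (the limit leaves the size open), resting on (the limit of > 100000 nM in this assay, at which 3 of the 3 values shown sit). Compound 4 is expected to give 100000 nM, most likely reported once more as a limit.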

Compound 4, half-maximal inhibitory concentration: > 100000 nM
Compound 4: a limit, no number (the forecaster's own chance of this, stated with the estimate: 85%); the middle value lies on the limit itself.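

Compound 4 gives only a limit of the assay, not a number, as do compound 2 and compound 3, so neither step to compound 4 can be read: the limit of > 100000 nM in this assay, at which 4 of the 4 values shown sit.

The compounds shown leave open whether either change, in the amide-type nitrogen's aryl group or the ring nitrogen's substituent, alters the half-maximal inhibitory concentration at all.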